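Branching the amino substituent on the shared core

The source may hold more compounds than are shown below. What is called first, only, known or untested is meant among the compounds shown, and "the series" means these compounds.

Compound 1 `CCCNc1ccc(O)c2ccccc12` carries a propylamino group; in an in vitro assay on P815B cells for inhibition of Indoleamine 2,3-dioxygenase 1 (Mus musculus), read by HPLC (a lower number here means a stronger inhibitor, a higher number a weaker inhibitor), compound 1 is reported as "not active" (no number reported). For the measured compounds named here, compound 2 `CC(C)Nc1ccc(O)c2ccccc12` gives 30000 nM in this assay, the only number so far, the other entry carrying no number. Compound 3 `CC(C)(C)Nc1ccc(O)c2ccccc12` differs from compound 2 by methyl in place of hydrogen on a saturated chain carbon bound to a nitrogen on an aromatic ring and two saturated chain carbons. Going by the values given here, no measured pair in this set shows what such a change does here. The step is expected to be a 1.3-fold higher number from compound 2 to compound 3 (0.12 log units; within the scatter), small or slightly weakening, with a real chance that no number is returned at all. Compound 3 is expected at 40000 nM, within 10000 nM to 150000 nM.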

Compound 3, half-maximal inhibitory concentration: "not active" (no number reported)
Nothing numeric was reported for compound 3; there is nothing to compare the estimate with.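

For the compounds shown here, compound 3 returned no number, so no step from compound 2 to compound 3 can be read. As far as these compounds go, whether any amino substituent on the shared core improves on compound 2 stays open, and no supporting data bear on this result.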